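A few compounds are considered here, and "the series" means these few. Any claim that something is new, unique, unknown or untested is made for them only; others in the source may bear on it.

Working notes on the sulfonamide series.

Compound 1 `CNS(=O)(=O)c1ccccc1Nc1cc(-c2ccc3ccn(C)c3c2)c2nccnc2c1` and compound 2 `Cn1ccc2ccc(-c3cc(Nc4ccccc4S(=O)(=O)Nc4cncnc4)cc4nccnc34)cc21` share the core and differ only at the sulfonamide nitrogen. In an assay for inhibition of 6-phosphofructo-2-kinase/fructose-2,6-bisphosphatase 3 (Homo sapiens), read by ADP-Glo, with a stated time of 2 h (a higher number here means a weaker inhibitor, a lower number a stronger inhibitor), compound 1 gives 104 nM, while compound 2 gives 1690 nM. Among the measured compounds shown here, the one step measured so far, a 16-fold higher number from compound 1 to compound 2 (1.21 log units; beyond the scatter), is large and clearly beyond the scatter. For the measured compounds named here, compound 2 therefore stands as the higher of the two numbers, with compound 1 as its only neighbour.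

Compound 3 `CN(Cc1cncnc1)S(=O)(=O)c1ccccc1Nc1cc(-c2ccc3ccn(C)c3c2)c2nccnc2c1` is the next point. Relative to compound 2 the change is methyl((pyrimidin-5-yl)methyl)amino in place of (pyrimidin-5-yl)amino on a sulfonyl sulfur. The methyl of compound 1 returns, the pyrimidine of compound 2 stays but is carried by a methylene, and the sulfonamide hydrogen is gone. Going by the values given here, the only step that bears on this is the one from compound 1 to compound 2, which shows how much the direct pyrimidine on the nitrogen cost; nothing measured speaks to a methylene link or to a doubly substituted sulfonamide nitrogen. A partial recovery towards compound 1 is expected rather than a full one, and the move is expected to be a 4.2-fold lower number from compound 2 to compound 3 (0.63 log units; beyond the scatter). Compound 3 is estimated at 400 nM in this assay, within a range of 100 nM to 1600 nM.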

Compound 3, half-maximal inhibitory concentration: 62 nM
Compound 3: middle estimate off by 6.5-fold (0.81 log units), on the high side; the whole stated range lies above it.
By their numbers in this assay, from the lowest: compounds 3 and 1 (each within the scatter of the next); then compound 2.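

In this assay, the sulfonamide nitrogen of compound 1 accepts a further (pyrimidin-5-yl)methyl group in place of its hydrogen with no change beyond the scatter, a 1.7-fold lower number from compound 1 to compound 3 (0.22 log units; within the scatter), so a pyrimidine ring on this side of the sulfonyl sulfur is not in itself tied to the loss seen in compound 2. The step of a 27-fold lower number from compound 2 to compound 3 (1.44 log units; beyond the scatter) shows that the same ring can go with a far lower number when it is carried by a methylene on a nitrogen that also bears methyl and has no hydrogen-bond donor, but this change brings in the methylene and the methyl together, so their shares in the step cannot be separated. No measurement shown gives a reason for either step.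

Still open is how each part contributes: the compounds shown do not include (pyrimidin-5-yl)methyl on a nitrogen that keeps its hydrogen, or pyrimidin-5-yl on a nitrogen that also carries methyl. They also leave open whether the pyrimidine matters at all in this position, which a benzyl group, a longer ethylene link to the ring or a simple dimethylamino group on the sulfonyl sulfur would address.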